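Trading a double bond for a triple bond at the acid arm

The source may hold more compounds than are shown below. What is called first, only, known or untested is meant among the compounds shown, and "the series" means these compounds.

compound 1 `O=C(O)/C=C/c1ccc(Cn2cccn2)cc1OCCc1ccc2ccccc2c1`: 3300 nM
compound 2 `O=C(O)/C=C/c1ccc(Cn2ccnc2)cc1OCCc1ccc2ccccc2c1`: > 10000 nM

Within the data shown here, in an assay on CHO cells for displacement of a labelled ligand from prostaglandin E2 receptor EP2 subtype (Mus musculus), read by scintillation counting (a higher number here means a weaker inhibitor, a lower number a stronger inhibitor), compound 1 gives 3300 nM, the only number among the two values shown. Compound 2 gives in this assay only > 10000 nM, which is a limit of the assay (the limit of > 10000 nM in this assay, at which 1 of the 2 values shown sits). The step of an at least 3.0-fold higher number from compound 1 to compound 2 (0.48 log units; beyond the scatter) changes the ring on the saturated chain carbon and leaves the acid arm untouched. Compound 3 `O=C(O)C#Cc1ccc(Cn2cccn2)cc1OCCc1ccc2ccccc2c1` differs from compound 1 elsewhere: 2-carboxyethynyl in place of 2-carboxyethenyl on an aromatic carbon. Among the measured compounds shown here, no measured step bears on this change, so the expectation rests on compound 1 alone. Compound 3 is expected to give 5000 nM, between 1500 nM and 15000 nM. The expected step is a 1.5-fold higher number from compound 1 to compound 3 (0.18 log units; within the scatter).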

Compound 3, inhibition constant: > 10000 nM
Compound 3: a limit, no number; the forecaster's own chance of this, stated with the estimate: 25%; at least 2.0-fold (0.30 log units) between middle value and limit.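

Replacing 2-carboxyethenyl with 2-carboxyethynyl gives an at least 3.0-fold higher number from compound 1 to compound 3 (0.48 log units; beyond the scatter) in this assay, so the acid arm, untouched in the earlier pair, also responds to a single change. For compound 3, > 10000 nM is a limit of the assay, so the full size of this step stays unknown and compound 3 cannot be ranked against compound 2: the limit of > 10000 nM in this assay, at which 2 of the 3 values shown sit.

As far as these compounds go, whether 2-carboxyethyl, with a saturated chain, would restore a measurable number at this position remains open. So does the effect of an amide in place of the carboxylic acid.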